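Adding a methoxy group to the ring of compound 2

This account rests on a few compounds, and the source may have more. Where it says the series, first, only, none or still open, it means among the compounds named here.

Compound 1 `COc1cc(/C=C/C(O)=C/C(=O)c2c(O)cccc2OC)ccc1O` gives 1680 nM in an in vitro assay on cells for inhibition of Amine oxidase [flavin-containing] B (Homo sapiens), read by Amplex Red, with a stated time of 15 min; a lower number here means a stronger inhibitor, a higher number a weaker inhibitor.
Compound 2 `COc1cc(/C=C/C=C/C(=O)c2ccccc2O)ccc1O` gives 502 nM in this assay.

Compound 2 has the lowest of the two numbers, and compound 1 stands a clear step higher, beyond the scatter. Compound 3 `COc1cc(/C=C/C=C/C(=O)c2c(O)cccc2OC)ccc1O` follows from compound 2 by one change: methoxy in place of hydrogen on an aromatic carbon. For the measured compounds named here, no measured pair shows this change alone, so its effect is open. Compound 3 is expected to land somewhat weaker, a step of a 1.8-fold higher number from compound 2 to compound 3 (0.25 log units; within the scatter), near the scatter edge. Compound 3 is estimated at 900 nM, within 300 nM to 2700 nM.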

Compound 3, half-maximal inhibitory concentration: 486 nM
For compound 3 the middle estimate is 1.9-fold (0.27 log units) above the measured one, and the stated range covers the measured number.
By their numbers in this assay, from the lowest: compounds 3 and 2 (each within the scatter of the next); then compound 1.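

Methoxy in place of hydrogen on an aromatic carbon, ortho to a large group, gives a 1.0-fold lower number from compound 2 to compound 3 (0.01 log units; within the scatter) in this assay, so compounds 2 and 3 cannot be told apart and this position accepts a methoxy group. Hydrogen in place of hydroxy on the chain gives a 3.5-fold lower number from compound 1 to compound 3 (0.54 log units; beyond the scatter), so the higher number of compound 1 goes with the chain hydroxy, not the ring methoxy. Nothing at hand explains either result. Going by these compounds, whether an ethoxy group, an amine or a fluorine atom at this position would behave like methoxy remains open.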